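The source may hold more compounds than are shown below. What is called first, only, known or untested is meant among the compounds shown, and "the series" means these compounds.

Compound 1 `COc1cccc(/C=C/C(=O)c2sc(Nc3ccccc3)nc2C)c1` gives in a functional assay on PC-3 cells (Homo sapiens) for cytotoxicity, read by MTT assay (on this read-out higher numbers stand for weaker inhibition and lower numbers for stronger inhibition), the value > 25000 nM, which is a limit of the assay, not a number.
Compound 2 `COc1cc(/C=C/C(=O)c2sc(Nc3ccccc3)nc2C)cc(OC)c1OC` gives in this assay the value > 25000 nM, again only a limit.
Compound 3 `COc1cccc(/C=C/C(=O)c2sc(Nc3ccccc3C)nc2C)c1` gives in this assay the value > 25000 nM, likewise a limit.

Compound 3 differs from compound 1 by one change, (methyl in place of hydrogen on an aromatic carbon). The step that the two limits leave unreadable from compound 1 to compound 3 stays unreadable because the limit of > 25000 nM in this assay, at which 3 of the 3 values shown sit, hides its true size. The difference between the cores of compound 1 and compound 2 is not broken down here.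

Compound 4 `COc1cc(/C=C/C(=O)c2sc(Nc3ccc(C)cc3)nc2C)cc(OC)c1OC`, not yet measured, differs from compound 2 by methyl in place of hydrogen on an aromatic carbon. The place differs from the change into compound 3: there the methyl sits ortho to a large group, here para to a large group, so this is the same kind of change, not the same one. Since compound 2 shows only a limit and the earlier step gave no readable size, compound 4 is expected to sit near that limit as well, with an expected step that the limit leaves unreadable from compound 2 to compound 4. The estimate for compound 4 is 40000 nM.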

Compound 4, half-maximal inhibitory concentration: > 25000 nM
Compound 4: no number, only a limit (the forecaster's own chance of this, stated with the estimate: 80%); the middle value does not contradict the limit.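

Adding the methyl leaves the size of the step from compound 2 to compound 4 unreadable, because both results are limits rather than numbers: the limit of > 25000 nM in this assay, at which 4 of the 4 values shown sit.

The compounds shown leave open how strong any of them truly is, and whether methyl in place of hydrogen on the aromatic ring changes the read-out at all.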